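Aryl swap at the saturated ring carbon: pyridinyl analogue

The source may hold more compounds than are shown below. What is called first, only, known or untested is meant among the compounds shown, and "the series" means these compounds.

In a functional assay on HeLa cells (Homo sapiens) for cytotoxicity, read by MTT assay (on this read-out lower numbers stand for stronger inhibition and higher numbers for weaker inhibition), compound 1 `CCOC(=O)C12C(=O)OCC=C1COC2c1ccccc1` gives 12800 nM. Among the measured compounds shown here, compound 2 `CCOC(=O)C12C(=O)OCC=C1COC2c1cccs1` gives 30400 nM in this assay, the higher of the two numbers so far, separated from compound 1 by a 2.4-fold higher number from compound 1 to compound 2 (0.38 log units; beyond the scatter). Compound 3 `CCOC(=O)C12C(=O)OCC=C1COC2c1ccccn1` carries the change (pyridin-2-yl in place of thiophen-2-yl on a saturated ring carbon). For the measured compounds named here, the only step that bears on it is the aryl exchange at this same carbon, a 2.4-fold higher number from compound 1 to compound 2 (0.38 log units; beyond the scatter), which was modest; a step of similar size in either direction, or none beyond the scatter, is the expectation here. Compound 3 is therefore estimated at 20000 nM in this assay, range 7000 nM to 60000 nM, meaning an expected step of a 1.5-fold lower number from compound 2 to compound 3 (0.18 log units; within the scatter).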

Compound 3, half-maximal inhibitory concentration: 20700 nM
Estimate against measurement, compound 3: 1.0-fold (0.01 log units) below; low and high end bracket the measured number.
By their numbers in this assay, from the lowest: compounds 1, 3 and 2 (each within the scatter of the next, the first and the last beyond it).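

In this assay, pyridin-2-yl on this saturated ring carbon stays within the scatter of both earlier aryl groups, with a 1.5-fold lower number from compound 2 to compound 3 (0.17 log units; within the scatter) from thiophen-2-yl and a 1.6-fold higher number from compound 1 to compound 3 (0.21 log units; within the scatter) from phenyl. Of the three aryl groups, only phenyl and thiophen-2-yl lie beyond the scatter of each other, so the pyridine nitrogen gives no readable step here. Nothing available explains these small differences. Open, going by these compounds, is whether an aminomethyl group or a longer alkyl chain in place of the aryl ring at this carbon would leave this narrow band. Also open, on these data alone, is how replacing the ethoxycarbonyl group with a carboxylic acid would read.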